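The source may hold more compounds than are shown below. What is called first, only, known or untested is meant among the compounds shown, and "the series" means these compounds.

Measured in a functional assay on K562 cells (Homo sapiens) for cytotoxicity, read by trypan blue exclusion, with a stated time of 96 h; a lower number here means a stronger inhibitor, a higher number a weaker inhibitor:
- compound 1 `COC(=O)C(C)(C)Nc1cc(NS(=O)(=O)/C=C/c2c(OC)cc(OC)cc2OC)ccc1OC`: 300 nM
- compound 2 `COC(=O)C(Nc1cc(NS(=O)(=O)/C=C/c2c(OC)cc(OC)cc2OC)ccc1OC)c1ccc(Br)cc1`: 1000 nM
- compound 3 `COc1cc(OC)c(/C=C/S(=O)(=O)Nc2ccc(OC)c(NCC(=O)O)c2)c(OC)c1`: 20 nM

Of these three, compound 3 has the lowest number, 20 nM, and both of the others lie beyond the scatter from it. Compound 4 `COc1cc(OC)c(/C=C/S(=O)(=O)Nc2ccc(OC)c(NC(C(=O)O)c3ccc(Cl)cc3)c2)c(OC)c1` differs from compound 3 by one change: 4-chlorophenyl in place of hydrogen on a saturated chain carbon bound to a carbonyl carbon and a nitrogen on an aromatic ring. In words, this is 4-chlorophenyl in place of hydrogen on a saturated chain carbon bound to a carbonyl carbon and a nitrogen on an aromatic ring.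

For the measured compounds named here, no measured compound carries 4-chlorophenyl, or combines a phenyl-bearing group with the carboxy group at this site. The nearest guide is compound 2, which carries 4-bromophenyl there. The modest step of a 3.3-fold higher number from compound 1 to compound 2 (0.52 log units; beyond the scatter) came with that group, although the two compounds share a methyl ester. The large step of a 50-fold lower number from compound 2 to compound 3 (1.70 log units; beyond the scatter) is harder to use, as it removes the 4-bromophenyl and the ester together, and a 15-fold lower number from compound 1 to compound 3 (1.18 log units; beyond the scatter) also changes more than one feature. These steps cannot be separated, but together they point towards a higher number for compound 4.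

A modest rise is therefore expected, estimated as a 4.0-fold higher number from compound 3 to compound 4 (0.60 log units; beyond the scatter). For compound 4 the estimated value in this assay is 80 nM, with an expected range of 20 nM to 400 nM.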

Compound 4, half-maximal inhibitory concentration: 15 nM
For compound 4 the middle estimate is 5.3-fold (0.73 log units) above the measured one; the whole stated range lies above it.
By their numbers in this assay, from the lowest: compounds 4 and 3 (each within the scatter of the next); then compound 1; then compound 2.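

In this assay, the step to a compound carrying 4-chlorophenyl on this saturated chain carbon is a 1.3-fold lower number from compound 3 to compound 4 (0.12 log units; within the scatter), so compounds 3 and 4 cannot be told apart, and this carbon can carry an aromatic ring without any shift that exceeds the usual scatter. Compound 2 had left open whether such a ring at this site went with a weak result, but a ring-bearing compound now sits far from it, at a 67-fold lower number from compound 2 to compound 4 (1.82 log units; beyond the scatter), and also far from the compound without a ring, at a 20-fold lower number from compound 1 to compound 4 (1.30 log units; beyond the scatter); both steps change more than one feature, yet among these four compounds the two carboxy compounds have the lowest numbers and the two methyl esters the highest, with none going against this. No measurement shown here accounts for this result. On these data alone, what remains open is how much of those large steps belongs to the carboxy group alone, as no ester and its matching acid appear as a pair differing only in that group. Also open, as far as these compounds go, are whether the chlorine contributes anything, which an unsubstituted phenyl would test, and whether a primary amide could stand in place of the carboxy group.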